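Chain exchange from compound 1 to compound 3

A few compounds are considered here, and "the series" means these few. Any claim that something is new, unique, unknown or untested is made for them only; others in the source may bear on it.

Measured so far in a functional assay on HEL cells (Homo sapiens) for inhibition, read by MTT assay, with a stated time of 48 h; on this read-out higher numbers stand for weaker inhibition and lower numbers for stronger inhibition:
- compound 1 `O=C(CCCCOc1no[n+]([O-])c1S(=O)(=O)c1ccccc1)NO`: 1030 nM
- compound 2 `O=C(/C=C/COc1no[n+]([O-])c1S(=O)(=O)c1ccccc1)NO`: "not determined" (no result reported)

Among the compounds with values here, compound 1 holds the only number, since compound 2 has no result in this assay. Within the data shown here, no ranking is therefore possible, and no measured step exists to calibrate a structural change.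

Next in line is compound 3 `O=C(NO)OCCOCCOc1no[n+]([O-])c1S(=O)(=O)c1ccccc1`, which keeps the shared core. Here 2-((hydroxycarbamoyl)oxy)ethoxy stands in place of 2-(hydroxycarbamoyl)ethyl on a saturated chain carbon, two bonds along the chain from an oxygen on an aromatic ring: 2-((hydroxycarbamoyl)oxy)ethoxy in place of 2-(hydroxycarbamoyl)ethyl on a saturated chain carbon, two bonds along the chain from an oxygen on an aromatic ring.

The expectation rests on a single anchor, compound 1 at 1030 nM, and on the structural change alone. A moderate loss of inhibition is expected rather than a gain, though a result close to compound 1 would not be surprising. The estimated change is a 1.9-fold higher number from compound 1 to compound 3 (0.29 log units; within the scatter). For compound 3 the expected value is 2000 nM, with an estimated range of 500 nM to 8000 nM.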

Compound 3, half-maximal inhibitory concentration: 3730 nM
The estimate for compound 3 lay 1.9-fold (0.27 log units) below the measured number; measured number inside the range.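

In this assay the series now has its first measured step: 2-((hydroxycarbamoyl)oxy)ethoxy in place of 2-(hydroxycarbamoyl)ethyl on a saturated chain carbon, two bonds along the chain from an oxygen on an aromatic ring, gives a 3.6-fold higher number from compound 1 to compound 3 (0.56 log units; beyond the scatter). The position therefore responds to this exchange, but the loss is modest, and compound 3 still gives a defined value of 3730 nM on the shared core. The entering group differs from the leaving one in heavy atoms, oxygen count and hydrogen-bond acceptors all at once, so this single step cannot assign the loss to any one of these features, and nothing at hand explains it.

The compounds shown leave open whether chain length alone or the added oxygens account for the step, since no compound separates the two. Also open, from the compounds shown here alone, is how a longer all-carbon chain, an amine within the chain or a carboxylic acid in place of the hydroxycarbamoyl end would read at this position.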